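Thiophen-3-yl for thiophen-2-yl on two hydroxyphenyl cores

A few compounds are considered here, and "the series" means these few. Any claim that something is new, unique, unknown or untested is made for them only; others in the source may bear on it.

Compound 1 `Oc1ccc(-c2cc(-c3ccccc3)cc(-c3cccs3)n2)cc1` gives 4.9% in an assay on isolated protein for inhibition of DNA topoisomerase 1 (Homo sapiens), with a stated time of 30 min, tested at 100 uM; on this read-out lower numbers stand for a weaker effect and higher numbers for a stronger effect at the one concentration tested. Compound 2 `Oc1ccc(-c2cc(-c3ccccc3)cc(-c3ccsc3)n2)cc1` gives 20.4% in this assay. The change thiophen-3-yl in place of thiophen-2-yl on an aromatic carbon made a step of a number 15.5 percentage points higher from compound 1 to compound 2 (beyond the scatter). Compound 3 `Oc1cccc(-c2cc(-c3ccccc3)nc(-c3cccs3)c2)c1` gives 9.1%; the difference between its core and that of compound 1 is not broken down here. The values of compound 3 and compound 1 lie within the scatter of each other, while compound 2 sits beyond the scatter above compound 3. Compound 4 `Oc1cccc(-c2cc(-c3ccccc3)nc(-c3ccsc3)c2)c1` carries the change (thiophen-3-yl in place of thiophen-2-yl on an aromatic carbon), the same kind of change as before, though here the place is meta to a 3-hydroxyphenyl group rather than a 4-hydroxyphenyl group. For the measured compounds named here, a step of a number 12.9 percentage points higher from compound 3 to compound 4 (beyond the scatter) is expected, resting on the single earlier step of a number 15.5 percentage points higher from compound 1 to compound 2 (beyond the scatter) from compound 1. Compound 4 is estimated at 22%, between 8% and 40%.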

Compound 4, a percentage reported as inhibition, at one concentration (the size of the read-out at that concentration, not a potency): 6.9%
Compound 4: the middle estimate sits 15.1 percentage points above what was measured; the whole stated range lies above it.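

With the 3-hydroxyphenyl group in the molecule, thiophen-3-yl in place of thiophen-2-yl gives a number 2.2 percentage points lower from compound 3 to compound 4 (within the scatter) in this assay, so the rise seen on the core of compound 1 does not carry over to this core. The result of this change therefore cannot be transferred unchanged between the two cores: the same change on two cores in this assay, a number 15.5 percentage points higher (beyond the scatter) from compound 1 to compound 2 and a number 2.2 percentage points lower (within the scatter) from compound 3 to compound 4, 17.7 percentage points apart, beyond the scatter of two such steps

These two pairs do not show which feature of the cores separates the steps, and they set no rule for any other core. Still open, from the compounds shown here alone, is whether an amine or a carboxylic acid at the thiophene's place would move the read-out beyond the scatter on both cores. Readings at one concentration also show only a stronger or weaker effect at that concentration.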